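A few compounds are considered here, and "the series" means these few. Any claim that something is new, unique, unknown or untested is made for them only; others in the source may bear on it.

In an ADME assay on LLC-MK2 cells (Macaca mulatta) for cytotoxicity, read by spectrophotometry and crystal violet staining, with a stated time of 4 days (a higher number here means that more compound is tolerated, a lower number that less compound is tolerated), compound 1 (`CC(C)n1ncc2c(C(=O)Nc3cccc(C(N)=O)c3)cc(-c3cccs3)nc21`) gives 25000 nM. Compound 2 (`CC(C)n1ncc2c(C(=O)Nc3cccc(F)c3)cc(-c3cccs3)nc21`) gives > 200000 nM, which is a limit of the assay and not a number. Among the compounds with values here, these two compounds differ in one place, fluoro in place of carbamoyl on an aromatic carbon, and the only measured step is an at least 8.0-fold higher number from compound 1 to compound 2 (0.90 log units; beyond the scatter). Compound 3 (`CC(C)n1ncc2c(C(=O)Nc3cncnc3)cc(-c3cccs3)nc21`) keeps the shared core of compound 2 but carries pyrimidin-5-yl in place of 3-fluorophenyl on an amide-type nitrogen. The measured step bears on this change only loosely, though it also alters the aromatic group on that nitrogen. Compound 1, at 25000 nM, shows that a change in this aromatic group can go with much less compound being tolerated, so a modest move toward a lower number is expected, although no move beyond the scatter remains possible. The expected change is an at least 2.0-fold lower number from compound 2 to compound 3 (0.30 log units; that floor lies within the scatter), and it is a loose estimate, as the starting point is only a limit. For compound 3 the estimated value is 100000 nM, with an expected range from 30000 nM to 200000 nM.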

Compound 3, half-maximal cytotoxic concentration: 20000 nM
Estimate against measurement, compound 3: 5.0-fold (0.70 log units) above; measured number below the stated range.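

In this assay, pyrimidin-5-yl in place of 3-fluorophenyl on the amide-type nitrogen gives an at least 10-fold lower number from compound 2 to compound 3 (1.00 log units; beyond the scatter), so a second replacement of 3-fluorophenyl at this place, after the 3-carbamoylphenyl of compound 1, also goes with much less compound being tolerated. Within the data shown here, the two replacements end up level, with a 1.3-fold lower number from compound 1 to compound 3 (0.10 log units; within the scatter), even though one is a ring of carbon only that carries a carbamoyl group and the other is an aromatic ring with hetero atoms and no such group. Compound 2 is the only one of the three that sits at a limit and not at a number, so the step down from it has a floor but no known full size: the limit of > 200000 nM in this assay, at which 1 of the 3 values shown sits.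

The compounds shown leave open whether the fluoro group itself goes with the high tolerance, or whether any plain aromatic ring would do the same, which an unsubstituted phenyl or a 3-chlorophenyl group on this nitrogen would help to settle. As far as these compounds go, it also stays open whether a 3-aminophenyl or a 3-carboxyphenyl group would land level with compound 1 and compound 3 or nearer the limit of compound 2.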